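The compounds below may be only part of what the source reports. "The series", "measured", "known", "first", "only" and "open" are said of these compounds alone.

Among the compounds with values here, compound 1 `O=C1NC(=O)N(Cc2ccccc2)/C1=C\c1ccccc1` stands highest of the two numbers so far in a functional assay on A549 cells (Homo sapiens) for antiproliferative activity, read by trypan blue exclusion, with a stated time of 72 h, tested at 20 uM (a higher number here means more inhibition at the concentration tested (going by the name of the read-out), a lower number less inhibition), where compound 1 gives 42%. Within the data shown here, its nearest neighbour, compound 2 `O=C1NC(=O)N(Cc2ccccc2)/C1=C\c1ccc(O)cc1`, gives 32% in this assay, and the only measured step, a number 10 percentage points lower from compound 1 to compound 2 (within the scatter), stays within the scatter. Compound 3 `CCCCN1C(=O)NC(=O)/C1=C/c1ccccc1` differs from compound 1 by propyl in place of phenyl on a saturated chain carbon bound to an amide-type nitrogen in a ring. Among the measured compounds shown here, no measured step touches this place on the core, so nothing measured bears on the change; the one step available lies elsewhere and was itself within the scatter. For compound 3 the expected step is therefore a number 2 percentage points lower from compound 1 to compound 3 (within the scatter), none beyond the scatter. Compound 3 is estimated at 40%, with a range from 20% to 60%.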

Compound 3, a percentage reported as inhibition, at one concentration (the size of the read-out at that concentration, not a potency): 18%
For compound 3 the middle estimate is 22 percentage points above the measured one, and the stated range ends above it.
By their numbers in this assay, from the lowest: compound 3; then compounds 2 and 1 (each within the scatter of the next).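

In this assay, within the data shown here, this is the first change to go beyond the scatter: with propyl in place of phenyl on a saturated chain carbon bound to an amide-type nitrogen in a ring, the step reads a number 24 percentage points lower from compound 1 to compound 3 (beyond the scatter). This place on the core therefore responds to the change, and butyl does not stand in for benzyl here. Nothing available accounts for the difference.

Open, from the compounds shown here alone, is whether the aromatic ring or the number of carbons matters more. A cyclohexylmethyl group or a longer chain such as hexyl at this place would separate the two.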